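This account rests on a few compounds, and the source may have more. Where it says the series, first, only, none or still open, it means among the compounds named here.

Measured so far in an ADME assay on Vero cells (Chlorocebus sabaeus) for cytotoxicity, with a stated time of 7 days; a lower number here means that less compound is tolerated, a higher number that more compound is tolerated:
compound 1 `COc1ccc2[nH]c(C(=O)N3CC(=O)N(Cc4ccccc4)[C@@H](COCc4ccccc4)C3)cc2c1`, > 30000 nM
compound 2 `O=C(c1cc2cc(C3CC3)ccc2[nH]1)N1CC(=O)N(Cc2ccccc2)[C@@H](CN2CCN(Cc3ccccc3)CC2)C1`, 5500 nM
compound 3 `COc1ccc2[nH]c(C(=O)N3CC(=O)N(Cc4ccccc4)[C@@H](N4CCC(Cc5ccccc5)CC4)C3)cc2c1`, > 30000 nM

Compound 1 sits at the limit of this assay, a ceiling and not a number. The same holds for compound 3, so two of the three values shown are limits, as the limit of > 30000 nM in this assay, at which 2 of the 3 values shown sit, records. Going by the values given here, compound 2 is the only compound of the three with a numbered value in this assay, and that value lies below the limit.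

Compound 4 `COc1ccc2[nH]c(C(=O)N3CC(=O)N(Cc4ccccc4)[C@@H](CN4CC5CCCCC5C4)C3)cc2c1` is compound 1 with a group of 9 heavy atoms (8 carbon, 1 nitrogen; one five-membered non-aromatic ring with 1 hetero atom, one six-membered non-aromatic ring of carbon only) in place of a group of 8 heavy atoms (7 carbon, 1 oxygen; one six-membered aromatic ring of carbon only), on a saturated chain carbon bound to a saturated ring carbon.

Among the compounds with values here, no step between two measured compounds that differ in a single place is available, so the size of this change in this assay cannot be read from the data. A shift toward less tolerated compound, of a size around the scatter, is expected, with a fair chance that only the limit is reported again. The estimated step from compound 1 to compound 4 is an at least 1.5-fold lower number from compound 1 to compound 4 (0.17 log units; that floor lies within the scatter). For compound 4 the estimate in this assay is 20000 nM, within 8000 nM to 30000 nM.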

Compound 4, half-maximal cytotoxic concentration: 8200 nM
The estimate for compound 4 lay 2.4-fold (0.39 log units) above the measured number; measured number inside the range.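

In this assay, exchanging benzyloxy for the group of 9 heavy atoms, on a saturated chain carbon bound to a saturated ring carbon, gives the only readable step shown: an at least 3.6-fold lower number from compound 1 to compound 4 (0.56 log units; beyond the scatter). This place is therefore not silent in this assay, as a change here alone moves the number beyond the scatter. The step gives only a minimum size, and its true size cannot be read: the limit of > 30000 nM in this assay, at which 2 of the 4 values shown sit.

Whether the nitrogen or the saturated rings of the entering group account for the step remains open. On these data alone, how a morpholine or a carboxylic acid at this place would read in this assay also remains open.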